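Replacing a chlorophenyl amide with a piperidinylacetyl group

The source may report more compounds than this note shows. Statements on the series, on what has been measured and on what is new or still open speak of the compounds shown alone.

In a functional assay on MGC-803 cells (Homo sapiens) for cytotoxicity, read by MTT assay, with a stated time of 48 h (a lower number here means a stronger inhibitor, a higher number a weaker inhibitor), compound 2 `O=C(c1ccccc1Cl)N1N=C(c2cc3ccccc3oc2=O)CC1c1ccccc1` gives 6640 nM and so has the lowest of the two numbers recorded. Among the compounds with values here, the only other measured compound, compound 1 `CC(=O)Oc1ccccc1C1CC(C)=NN1C(=O)CN(C(C)C)C(C)C`, gives 20100 nM in this assay, a difference that lies beyond the usual scatter; the two share no single-point change, so nothing more than the two values themselves can be compared.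

Compound 3 `NC(=O)C1CCN(CC(=O)N2N=C(c3cc4ccccc4oc3=O)CC2c2ccccc2)CC1` has not yet been measured. It differs from compound 2 by one counted change: (4-carbamoylpiperidin-1-yl)methyl in place of 2-chlorophenyl on a carbonyl carbon. Within the data shown here, since no measured pair shows this kind of change, there is no direct precedent for its size or direction. Compound 3 is expected to give a somewhat higher number, with the step of a 1.7-fold higher number from compound 2 to compound 3 (0.22 log units; within the scatter) estimated to be small and possibly within the scatter. The estimate for compound 3 is 11000 nM, with a range from 3500 nM to 35000 nM.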

Compound 3, half-maximal inhibitory concentration: 21500 nM
The estimate for compound 3 lay 2.0-fold (0.29 log units) below the measured number; the range from low to high includes it.
By their numbers in this assay, from the lowest: compound 2; then compounds 1 and 3 (each within the scatter of the next).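

In this assay, within the data shown here, the change gives the first measured step at this carbonyl carbon, whose other neighbour is the amide-type nitrogen in a ring: the swap of 2-chlorophenyl for (4-carbamoylpiperidin-1-yl)methyl produces a 3.2-fold higher number from compound 2 to compound 3 (0.51 log units; beyond the scatter) and so shows that the number here depends on the group attached. Among these compounds, the single step replaces an aromatic carbon ring with a non-aromatic ring carrying a hydrogen-bond donor and acceptors, so it cannot separate the contributions of these differences. No available measurement explains the rise.

Going by these compounds, it remains open whether the 2-chloro substituent matters, which a plain phenyl group would test, or whether the carboxamide does, which an unsubstituted piperidin-1-ylmethyl group would test. A benzyl group, which would place a methylene before an aromatic ring, is equally untested at this position.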